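Thiophene in place of nitrophenyl on the dihydropyridine core

A few compounds are considered here, and "the series" means these few. Any claim that something is new, unique, unknown or untested is made for them only; others in the source may bear on it.

Measured so far:
- compound 1 `COc1cc(N2C(N)=C(C#N)C(c3ccc([N+](=O)[O-])cc3)C3=C2CC(C)(C)CC3=O)cc(OC)c1OC`: 25000 nM
- compound 2 `COc1ccc(C2C(C#N)=C(N)N(c3cc(OC)c(OC)c(OC)c3)C3=C2C(=O)CC(C)(C)C3)cc1`: "not active" (no number reported)

Among the measured compounds shown here, compound 1 carries a 4-nitrophenyl group on the saturated ring carbon of its core and gives 25000 nM in a functional assay on Ehrlich cells (Mus musculus) for cytotoxicity; a lower number here means a stronger inhibitor, a higher number a weaker inhibitor; it is the only compound of the series with a number at all. Compound 2, which carries a 4-methoxyphenyl group at the same place, is recorded in this assay as "not active" (no number reported), with no number behind it. For the measured compounds named here, with only one number, no step between measured compounds can be stated, and compound 1 stands simply as the one entry that was quantified, a weak inhibitor on its own terms.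

Compound 3 `COc1cc(N2C(N)=C(C#N)C(c3cccs3)C3=C2CC(C)(C)CC3=O)cc(OC)c1OC` is not yet measured. It differs from compound 1 in one place: thiophen-2-yl in place of 4-nitrophenyl on a saturated ring carbon.

Neither the number for compound 1 nor the absence of one for compound 2 gives a basis for a directed step, so the expectation for the change in this assay is a shift no larger than the usual scatter, with a real chance that compound 3, like compound 2, yields no number. The estimate for compound 3 is 30000 nM, between 8000 nM and 120000 nM, which means an expected step of a 1.2-fold higher number from compound 1 to compound 3 (0.08 log units; within the scatter).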

Compound 3, half-maximal inhibitory concentration: "not active" (no number reported)
The entry for compound 3 holds no number, so the estimate cannot be set against anything.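

In this assay, among the compounds shown here, compound 3, like compound 2, is recorded as "not active" with no number, so no step from compound 1 at 25000 nM can be read. From the compounds shown here alone, how thiophen-2-yl compares in size of effect with 4-nitrophenyl on the shared core stays open. No measurement shown offers an explanation for this result.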